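The compounds below may be only part of what the source reports. "The series", "measured", "known", "first", "only" and "open" are said of these compounds alone.

Measured so far in a functional assay on B16 cells (Mus musculus) for inhibition; on this read-out higher numbers stand for weaker inhibition and lower numbers for stronger inhibition:
- compound 1 `COc1cc(/C=C/C(=O)c2cccc(NC(=O)c3ccc(Cl)cc3)c2)ccc1O`: 0.59 ug/mL
- compound 2 `COc1cc(/C=C/C(=O)c2cccc(N)c2)ccc1O`: 11.5 ug/mL
- compound 3 `COc1cc(/C=C/C(=O)c2cccc(NC(=O)C(C)C)c2)ccc1O`: 1.09 ug/mL

On these numbers compound 3 cannot be told apart from compound 1, while an 11-fold lower number from compound 2 to compound 3 (1.02 log units; beyond the scatter) sets it clearly apart from compound 2. The next compound to be tested is compound 4 `COC(=O)C(=O)Nc1cccc(C(=O)/C=C/c2ccc(O)c(OC)c2)c1`, and the change is methoxycarbonyl in place of isopropyl on a carbonyl carbon.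

Within the data shown here, the closest precedent is a 1.8-fold higher number from compound 1 to compound 3 (0.27 log units; within the scatter), a swap on that same carbonyl carbon that stayed within the scatter. The large steps, a 19-fold higher number from compound 1 to compound 2 (1.29 log units; beyond the scatter) and an 11-fold lower number from compound 2 to compound 3 (1.02 log units; beyond the scatter), concern removing or adding the whole group on the nitrogen, and compound 4 keeps that carbonyl. Among the measured compounds shown here, only one swap at this place has been measured, so the evidence is thin, and no step beyond the scatter is expected in this assay. The expected change is a 1.3-fold higher number from compound 3 to compound 4 (0.11 log units; within the scatter). For compound 4 the estimated value is 1.4 ug/mL, with an expected range of 0.5 ug/mL to 4 ug/mL.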

Compound 4, half-maximal inhibitory concentration: 4.41 ug/mL
Beside the measured number, compound 4's estimate is 3.2-fold (0.50 log units) below it; measured number outside the range, above it.
By their numbers in this assay, from the lowest: compounds 1 and 3 (each within the scatter of the next); then compound 4; then compound 2.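

In this assay the group on this carbonyl carbon turns out to matter: there is a 4.0-fold higher number from compound 3 to compound 4 (0.61 log units; beyond the scatter) and also a 7.5-fold higher number from compound 1 to compound 4 (0.87 log units; beyond the scatter), whereas the earlier swap of isopropyl for 4-chlorophenyl at the same place stayed within the scatter. Methoxycarbonylcarbonyl on the nitrogen still improves on plain hydrogen, with a 2.6-fold lower number from compound 2 to compound 4 (0.42 log units; beyond the scatter), but this gain is smaller than the one seen with isopropylcarbonyl, an 11-fold lower number from compound 2 to compound 3 (1.02 log units; beyond the scatter). Nothing available explains why methoxycarbonyl behaves differently here.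

The compounds shown do not separate the effect of the added carbonyl from that of its methyl ester end, since only one such group appears. As far as these compounds go, whether a carboxylic acid, a primary amide or an ethoxycarbonyl at this carbonyl carbon would follow compound 4 or return towards compound 3 stays open.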